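Swapping Methyl for Bromo: Expected Cytotoxicity of Compound 4

This account rests on a few compounds, and the source may have more. Where it says the series, first, only, none or still open, it means among the compounds named here.

Of the compounds shown here, three built on one shared core have so far been tested in an ADME assay on HEL cells (Homo sapiens) for cytotoxicity; on this read-out lower numbers stand for higher toxicity in this test and higher numbers for lower toxicity in this test. Compound 1 `C/C(=N\NC(=O)COc1cccc2ccccc12)c1ccc(C#N)cc1Br` gives 12.7 ug/mL in this assay. Compound 2 `O=C(COc1cccc2ccccc12)N/N=C/c1c(O)ccc2ccccc12` gives 1.94 ug/mL in this assay. Compound 3 `Cc1ccc(/C=N/NC(=O)COc2cccc3ccccc23)cc1` gives 80.1 ug/mL in this assay, the highest of the three numbers and so the least toxic in this test; its nearest neighbour is compound 1, whose number is lower by more than the usual scatter, and compound 2 stands furthest from it, again beyond the scatter.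

Compound 4 `O=C(COc1cccc2ccccc12)N/N=C/c1ccc(Br)cc1` has not yet been measured. It differs from compound 3 in a single place: bromo in place of methyl on an aromatic carbon. Among the measured compounds shown here, no measured pair shows this same exchange, so its effect cannot be read from the data; the change is small in size, one heavy atom for one heavy atom. The step of a 1.5-fold lower number from compound 3 to compound 4 (0.16 log units; within the scatter) is expected to be small, pointing toward a somewhat lower number, yet not beyond the scatter. Compound 4 is therefore expected to give about 55 ug/mL in this assay, in a range from 20 ug/mL to 150 ug/mL.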

Compound 4, half-maximal cytotoxic concentration: 100 ug/mL
Compound 4: middle estimate off by 1.8-fold (0.26 log units), on the low side; measured number inside the range.
By their numbers in this assay, from the lowest: compound 2; then compound 1; then compounds 3 and 4 (each within the scatter of the next).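

In this assay, bromo in place of methyl on this aromatic carbon, para to a large group, gives a 1.2-fold higher number from compound 3 to compound 4 (0.10 log units; within the scatter), the first direct view of this exchange on the shared core. At this one position, then, going from 4-methylphenyl to 4-bromophenyl leaves the read-out indistinguishable from repeat-measurement noise, so the two groups cannot be told apart in this test. Among the compounds shown here, nothing measured so far offers an explanation for this result.

Methyl and bromo each count one heavy atom and no hydrogen-bond donors or acceptors, and it remains open whether an amine, a carboxylic acid or a longer chain at this position would leave the number just as unchanged. Also open, as far as these compounds go, is which feature of compound 1 or compound 2 goes with their lower numbers, as each differs from compound 3 in more than one place.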